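Replacing the aryl group of compound 3

This account rests on a few compounds, and the source may have more. Where it says the series, first, only, none or still open, it means among the compounds named here.

Among the compounds with values here, in a functional assay on Jurkat cells (Homo sapiens) (on this read-out lower numbers stand for stronger inhibition and higher numbers for weaker inhibition), compound 3 (`CC(C)[C@H](NC(=O)COc1cccc2ccccc12)C(=O)N[C@@H](CC(=O)O)C(=O)COc1ccc(OC(F)(F)F)cc1`) gives 29100 nM, the only value so far that is not a limit. Compound 1 (`CC(C)[C@H](NC(=O)COc1cccc2ccccc12)C(=O)N[C@@H](CC(=O)O)C(=O)COc1ccccc1C(F)(F)F`) reads > 100000 nM, which is a limit of the assay. Compound 2 (`CC(C)[C@H](NC(=O)COc1cccc2ccccc12)C(=O)N[C@@H](CC(=O)O)C(=O)COc1ccc(C(N)=O)cc1`) reads > 100000 nM, also a limit. Compound 4 (`CC(C)[C@H](NC(=O)COc1cccc2ccccc12)C(=O)N[C@@H](CC(=O)O)C(=O)COc1ccccc1F`) differs from compound 3 as follows: 2-fluorophenyl in place of 4-(trifluoromethoxy)phenyl on an oxygen on a saturated carbon. Two measured steps change this same group: an at least 3.4-fold lower number from compound 2 to compound 3 (0.53 log units; beyond the scatter) and, starting from the closest match, 2-(trifluoromethyl)phenyl, an at least 3.4-fold lower number from compound 1 to compound 3 (0.53 log units; beyond the scatter). Reversing that second step suggests weaker inhibition in this assay, and the expected step is a 1.9-fold higher number from compound 3 to compound 4 (0.28 log units; within the scatter). Compound 4 is estimated at 55000 nM, with an expected range of 15000 nM to 100000 nM.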

Compound 4, half-maximal inhibitory concentration: > 100000 nM
Compound 4 was reported as a limit (the forecaster's own chance of this, stated with the estimate: 45%); middle value at least 1.8-fold (0.25 log units) from the limit.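

In this assay, 2-fluorophenyl in place of 4-(trifluoromethoxy)phenyl gives an at least 3.4-fold higher number from compound 3 to compound 4 (0.53 log units; beyond the scatter), and this step rests on a limit. Among the aryl groups shown on this oxygen, compound 3 therefore remains the only compound with a value that is not a limit. The steps among compound 1, compound 2 and compound 4 cannot be read, because all three stand at the same limit: the limit of > 100000 nM in this assay, at which 3 of the 4 values shown sit.

On these data alone, compound 4 differs from compound 3 in both the substituent and its printed ring position, so which of these matters remains open. As far as these compounds go, how a methoxy group or an amine on the phenyl ring would read in this assay is also open.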